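This account rests on a few compounds, and the source may have more. Where it says the series, first, only, none or still open, it means among the compounds named here.

Of the compounds shown here, three of one shared family have been tested in a functional assay on MT4 cells (Homo sapiens) for cytotoxicity, read by MTT assay, with a stated time of 5 days; on this read-out higher numbers stand for lower toxicity in this test and lower numbers for higher toxicity in this test. Compound 1 `N#Cc1ccc(Nc2nccc(Nc3ccc(-c4ccc(C#N)cc4)cc3F)n2)cc1` gives 308000 nM, the higher of the two plain numbers seen. Compound 3 `Cc1cc(Oc2ccnc(Nc3ccc(C#N)cc3)n2)ccc1-c1ccc(C#N)cc1` gives 29400 nM, a gap from compound 1 that lies beyond the usual scatter. Compound 2 `N#Cc1ccc(Nc2nccc(Oc3ccc(-c4ccc(C#N)cc4Cl)cc3Cl)n2)cc1` returns only a limit of the assay, > 273000 nM, so it is not a number that can be placed in order; this is the situation in the limit of > 273000 nM in this assay, at which 1 of the 3 values shown sits.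

Compound 4 `COc1cc(-c2ccc(C#N)cc2)ccc1Nc1ccnc(Nc2ccc(C#N)cc2)n1` is the untested member. It differs from compound 1 in one spot: methoxy in place of fluoro on an aromatic carbon, a methoxy in place of fluoro on an aromatic carbon. For the measured compounds named here, no measured pair shows the effect of exactly this swap, so the expectation rests on the spread of what has been seen. In this assay compound 4 is expected to give 180000 nM, somewhere between 50000 nM and 400000 nM, which means a step from compound 1 of a 1.7-fold lower number from compound 1 to compound 4 (0.23 log units; within the scatter) is expected, a modest fall that may still lie within the scatter.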

Compound 4, half-maximal cytotoxic concentration: > 298000 nM
Compound 4: no number, only a limit (the forecaster's own chance of this, stated with the estimate: 25%); middle value at least 1.6-fold (0.21 log units) from the limit.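

In this assay, for the compounds shown here, compound 4 returns only a limit, > 298000 nM, so no step from compound 1 to compound 4 can be read. The compounds shown leave open how far, if at all, methoxy in place of fluoro on an aromatic carbon shifts this read-out.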